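Alkene in the Pentyl Chain of a Vanilloid Receptor Antagonist

This account rests on a few compounds, and the source may have more. Where it says the series, first, only, none or still open, it means among the compounds named here.

Measured so far:
compound 1, `CCCCCc1nc(C(F)(F)F)ccc1CNC(=O)C(C)c1ccc(NS(C)(=O)=O)c(F)c1`: 1 nM
compound 2, `CC(C(=O)NCc1ccc(C(F)(F)F)nc1C1=CCC(C(C)(C)C)CC1)c1ccc(NS(C)(=O)=O)c(F)c1`: 0.2 nM

In an assay on CHO cells for antagonist activity at transient receptor potential cation channel subfamily V member 1 (Homo sapiens), read by FLIPR and calcium flux (on this read-out lower numbers stand for stronger inhibition and higher numbers for weaker inhibition), compound 1 gives the highest of the two numbers; its nearest neighbour is compound 2, reached by a 5.0-fold lower number from compound 1 to compound 2 (0.70 log units; beyond the scatter). Compound 3, `CCC/C=C\c1nc(C(F)(F)F)ccc1CNC(=O)C(C)c1ccc(NS(C)(=O)=O)c(F)c1`, is not yet measured. It differs from compound 1 by pent-1-en-1-yl in place of pentyl on an aromatic carbon. For the measured compounds named here, only the step from compound 1 to compound 2 offers guidance, and it changed pentyl to a ring rather than adding 1 double bond outside aromatic rings to the chain, so it bears on compound 3 only loosely. A small step, at most at the edge of the scatter, is expected: a 1.4-fold lower number from compound 1 to compound 3 (0.15 log units; within the scatter). Compound 3 is estimated at 0.7 nM, within 0.3 nM to 2 nM.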

Compound 3, inhibition constant: 2.1 nM
For compound 3 the middle estimate is 3.0-fold (0.48 log units) below the measured one; the whole stated range lies below it.
By their numbers in this assay, from the lowest: compound 2; then compound 1; then compound 3.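

Within this assay, one double bond outside aromatic rings in the chain, with the heavy-atom count unchanged, gives no gain at this position on an aromatic carbon next to the ring nitrogen (a 2.1-fold higher number from compound 1 to compound 3 (0.32 log units; beyond the scatter)). Pent-1-en-1-yl also falls well short of 4-(tert-butyl)cyclohex-1-en-1-yl (an 11-fold higher number from compound 2 to compound 3 (1.02 log units; beyond the scatter)), so a double bond at this position does not by itself match the low number of compound 2. The compounds shown leave open how the trans form of pent-1-en-1-yl, pent-1-yn-1-yl or saturated 4-(tert-butyl)cyclohexyl would compare here. No evidence shown accounts for either step.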